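Neopentyl in place of isopropyl on compound 1

A few compounds are considered here, and "the series" means these few. Any claim that something is new, unique, unknown or untested is made for them only; others in the source may bear on it.

Among the compounds with values here, in a functional assay (aorta) for inhibition, with Homo sapiens as the target, using microsomes, in the presence of a further agent that is not named here (a higher number here means a weaker inhibitor, a lower number a stronger inhibitor), compound 1 (`CCOC(=O)/C(C)=C\c1ccc(Cc2cccnc2)n1C(C)C`) gives 32000 nM as the higher of the two numbers measured so far. Compound 2 (`CCOC(=O)/C=C/c1cc(Cn2ccnc2)n(C)c1`) gives 1800 nM as the lower number, and the gap between the two lies beyond the scatter. Compound 1 is therefore the weaker inhibitor of the pair.

Compound 3 (`CCOC(=O)/C(C)=C\c1ccc(Cc2cccnc2)n1CC(C)(C)C`) has not yet been measured. It carries neopentyl in place of isopropyl on an aromatic nitrogen. The change sits on an aromatic nitrogen of a five-membered aromatic ring with 1 nitrogen, and the rest of compound 1 stays the same.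

Within the data shown here, no measured pair differs in one place only, so the data give no direct guide to the size of this change. Among the measured compounds shown here, the only anchor is compound 1 at 32000 nM in this assay. The expected change is a 1.3-fold lower number from compound 1 to compound 3 (0.11 log units; within the scatter) and it is not expected to exceed the scatter. In this assay the estimate for compound 3 is 25000 nM with 8000 nM to 70000 nM as the expected range.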

Compound 3, half-maximal inhibitory concentration: 57000 nM
Compound 3: middle estimate off by 2.3-fold (0.36 log units), on the low side; the range from low to high includes it.
By their numbers in this assay, from the lowest: compound 2; then compounds 1 and 3 (each within the scatter of the next).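

In this assay, within the data shown here, the first single-place step reads a 1.8-fold higher number from compound 1 to compound 3 (0.25 log units; within the scatter), so neopentyl in place of isopropyl on the aromatic nitrogen of the five-membered aromatic ring does not shift the read-out beyond the scatter. At this position, 5 heavy atoms in place of 3, all carbon and with no ring, therefore give values that cannot be told apart, and the two branched alkyl groups count as equivalent in this assay. No measurement in hand bears on why the two groups read alike.

As far as these compounds go, both groups are plain carbon chains, so it remains open whether a different kind of group on this nitrogen, such as a chain ending in an amine or a carboxylic acid, or a hydrogen in place of the alkyl group, would read differently from compound 1 at 32000 nM. Among these compounds, also open is how the other places on the core of compound 1 behave one at a time, for example the ethyl ester replaced by a carboxylic acid, since the only single-place step so far lies at this nitrogen.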